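The compounds below may be only part of what the source reports. "The series", "measured", "known", "first", "only" and "open" are said of these compounds alone.

Compound 2 `CCOC(=O)c1cccc(-c2ccc(O)cc2)c1` stands second highest of the three numbers in an assay on COS-7 cells for inhibition of patatin-like phospholipase domain-containing protein 2 (Mus musculus), tested at 200 uM; a higher number here means more inhibition at the concentration tested (going by the name of the read-out), a lower number less inhibition. Compound 1 `CCOC(=O)c1cccc(-c2ccc(OCC)cc2)n1` gives 79%, a value within the scatter of compound 2's own 77%, so no order between these two can be claimed. Compound 3 `CCOC(=O)c1cccc(-c2ccc(CN(C)C)o2)c1` gives 53%, which lies beyond the scatter and below compound 2. Compound 4 `CCOC(=O)c1cccc(-c2ccc(C(C)=O)cc2)c1` has not yet been measured. It differs from compound 2 by acetyl in place of hydroxy on an aromatic carbon, the change sitting on an aromatic carbon of a six-membered aromatic ring of carbon only, para to a large group. Among the measured compounds shown here, no step between measured compounds covers this change, so the direction is open; a modest fall or none beyond the scatter seems most likely. The step from compound 2 to compound 4 is expected to be about a number 7 percentage points lower from compound 2 to compound 4 (within the scatter). Compound 4 is estimated at 70%, with a range from 50% to 85%.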

Compound 4, a percentage reported as inhibition, at one concentration (the size of the read-out at that concentration, not a potency): 36%
Compound 4: the middle estimate sits 34 percentage points above what was measured; the whole stated range lies above it.
By their numbers in this assay, from the lowest: compound 4; then compound 3; then compounds 2 and 1 (each within the scatter of the next).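

In this assay, acetyl in place of hydroxy on this aromatic carbon gives a number 41 percentage points lower from compound 2 to compound 4 (beyond the scatter), so the group at this place clearly matters and the two groups are not interchangeable. The change removes a hydrogen-bond donor and adds heavy atoms in one move, and this single step cannot separate those two differences. No measurement shown explains the fall. Going by these compounds, whether an amine or a carboxylic acid on this carbon would hold the number near that of compound 2 remains open, as does whether a methoxy group would.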